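A few compounds are considered here, and "the series" means these few. Any claim that something is new, unique, unknown or untested is made for them only; others in the source may bear on it.

Compound 3 `O=c1c2ccccc2[se]n1-c1nnc(-c2ccccc2Br)s1` gives 59400 nM in a functional assay on MCF7 cells (Homo sapiens) for antiproliferative activity, read by CCK-8 assay, with a stated time of 48 h (on this read-out lower numbers stand for stronger inhibition and higher numbers for weaker inhibition), the highest of the three numbers measured. Compound 1 `Cc1ccc(-c2nnc(-n3[se]c4ccccc4c3=O)s2)cc1` gives 18700 nM and compound 2 `O=c1c2ccccc2[se]n1-c1nnc(-c2cccc([N+](=O)[O-])c2)s1` gives 29200 nM. Within the data shown here, the only measured step in one place is a 3.2-fold higher number from compound 1 to compound 3 (0.50 log units; beyond the scatter). Compound 4 `Cc1cccc(-c2nnc(-n3[se]c4ccccc4c3=O)s2)c1` is built from compound 3 by 3-methylphenyl in place of 2-bromophenyl on an aromatic carbon. A lower number is expected for compound 4, roughly undoing that earlier step, because a 3.2-fold higher number from compound 1 to compound 3 (0.50 log units; beyond the scatter) is the step that this change largely reverses: there 4-methylphenyl gave way to 2-bromophenyl, and here a methyl-bearing phenyl, 3-methylphenyl, returns. For compound 4 the estimated value is 22000 nM, with a range from 9000 nM to 55000 nM, which means an expected step of a 2.7-fold lower number from compound 3 to compound 4 (0.43 log units; beyond the scatter).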

Compound 4, half-maximal inhibitory concentration: 19900 nM
Estimate against measurement, compound 4: 1.1-fold (0.04 log units) above; low and high end bracket the measured number.
By their numbers in this assay, from the lowest: compounds 1, 4 and 2 (each within the scatter of the next); then compound 3.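

In this assay, the step of a 3.0-fold lower number from compound 3 to compound 4 (0.47 log units; beyond the scatter) shows that the gap to 2-bromophenyl at this position is not peculiar to 4-methylphenyl, since 3-methylphenyl opens it too. With a 1.1-fold higher number from compound 1 to compound 4 (0.03 log units; within the scatter), the two methylphenyl groups cannot be told apart here, and a 1.5-fold lower number from compound 2 to compound 4 (0.17 log units; within the scatter) likewise leaves methyl and nitro on the phenyl ring unresolved. No measurement given explains these differences. Going by these compounds, whether the weaker result of compound 3 follows from bromine itself or from where it sits remains open. A 2-methylphenyl or 3-bromophenyl group could separate those readings, while an amine or carboxylic acid on the phenyl ring remains untested in the compounds shown.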